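The source may hold more compounds than are shown below. What is called first, only, known or untested is meant among the compounds shown, and "the series" means these compounds.

Three hydroxamic acids were measured in an assay on isolated protein for inhibition of protein deacetylase HDAC6 (Homo sapiens), read by fluorescence, with a stated time of 15 min; a higher number here means a weaker inhibitor, a lower number a stronger inhibitor. Compound 1 `O=C(NO)c1cccc(/C=C/c2ccnc(-c3ccccc3O)c2)c1` gives 390 nM. Compound 3 `O=C(NO)c1ccc(/C=C/c2cccc(-c3cc(F)ccc3O)c2)cc1` gives 240 nM. Compound 2 `O=C(NO)c1ccc(/C=C/c2ccnc(-c3cccc(CO)c3)c2)cc1` gives 34 nM, the lowest of the three numbers: compound 3 lies higher by a gap beyond the scatter, and compound 1 higher still, also beyond the scatter. Among the compounds with values here, no single-point step between any two of these measured compounds is available, so the comparison of their values is all that can be read from them.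

Compound 4 `O=C(NO)c1ccc(/C=C/c2ccnc(-c3ccsc3)c2)cc1` differs from compound 2 in one place: thiophen-3-yl in place of 3-(hydroxymethyl)phenyl on an aromatic carbon. The group that leaves carries the only hydrogen-bond donor on that ring, and the ring itself shrinks from six members to five; whether this matters for this assay cannot be judged from the three measured compounds. The step from compound 2 to compound 4 is expected to be modest and toward a higher number, as a 2.4-fold higher number from compound 2 to compound 4 (0.37 log units; beyond the scatter). For compound 4 the estimated value is 80 nM, with a range from 30 nM to 250 nM.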

Compound 4, half-maximal inhibitory concentration: 54 nM
For compound 4 the middle estimate is 1.5-fold (0.17 log units) above the measured one, and the stated range covers the measured number.
By their numbers in this assay, from the lowest: compounds 2 and 4 (each within the scatter of the next); then compounds 3 and 1 (each within the scatter of the next).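

In this assay, the change at this position, on an aromatic carbon next to the ring nitrogen, gives a 1.6-fold higher number from compound 2 to compound 4 (0.20 log units; within the scatter), so the two compounds cannot be told apart. Within the data shown here, for this pair, the number therefore holds when the six-membered aromatic ring of carbon only, with its hydroxymethyl group and hydrogen-bond donor, gives way to the five-membered thiophen-3-yl ring, which has no such donor; the three earlier compounds, with no single-place step among them, could not show this. Nothing measured here explains why the two numbers lie so close.

The compounds shown leave open whether this tolerance extends to other groups at the same carbon, such as an aminomethyl group or a carboxylic acid on the phenyl ring. They also leave open whether a saturated ring such as piperidine would fit in the same way.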